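Moving the pyridine nitrogen in a benzamide thiocarbamate series

The compounds below may be only part of what the source reports. "The series", "measured", "known", "first", "only" and "open" are said of these compounds alone.

Measured compounds:
- compound 1 `Nc1ccccc1NC(=O)c1ccc(CSC(=S)N2CCc3cc(Cl)ccc32)cc1`: 40.1%
- compound 2 `CC1CCCCN1C(=S)SCc1ccc(C(=O)Nc2ccccc2N)cc1`: 45.5%
- compound 3 `CN(Cc1ccncc1)C(=S)SCc1ccc(C(=O)Nc2ccccc2N)cc1`: 29.5%

These values come from a functional assay on HeLa cells (Homo sapiens) for antiproliferative activity, read by CCK-8 assay, with a stated time of 72 h, tested at 2 uM; a lower number here means a weaker effect, a higher number a stronger effect of the compound at the concentration tested. Compound 3 stands lowest of the three; the step of a number 10.6 percentage points lower from compound 1 to compound 3 (beyond the scatter) and the step of a number 16 percentage points lower from compound 2 to compound 3 (beyond the scatter) both lie beyond the scatter, while the step of a number 5.4 percentage points higher from compound 1 to compound 2 (within the scatter) does not. Compound 4 `CN(Cc1cccnc1)C(=S)SCc1ccc(C(=O)Nc2ccccc2N)cc1` differs from compound 3 only in pyridin-3-yl in place of pyridin-4-yl on a saturated chain carbon bound to an amide-type nitrogen. Within the data shown here, no measured step exchanges one pyridinyl for another; the two steps into compound 3 replaced the whole amine group and were modest in size. Such a small rearrangement is therefore expected to give a step within the scatter, a number 0.5 percentage points higher from compound 3 to compound 4 (within the scatter). For compound 4 an inhibition of 30% is estimated, in a range of 15% to 45%.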

Compound 4, a percentage reported as inhibition, at one concentration (the size of the read-out at that concentration, not a potency): 16.4%
Compound 4: middle estimate off by 13.6 percentage points, on the high side; the range from low to high includes it.
By their numbers in this assay, from the lowest: compound 4; then compound 3; then compounds 1 and 2 (each within the scatter of the next).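

In this assay the ring nitrogen's location alone proves to matter: with the same atoms joined differently, pyridin-3-yl in place of pyridin-4-yl gives a number 13.1 percentage points lower from compound 3 to compound 4 (beyond the scatter) and lies beyond the scatter. Replacing the whole amine group with methyl((pyridin-3-yl)methyl)amino gives a number 29.1 percentage points lower from compound 2 to compound 4 (beyond the scatter) and also a number 23.7 percentage points lower from compound 1 to compound 4 (beyond the scatter) on the same thiocarbonyl carbon, which leaves compound 4 the weakest of the four. On these data alone, how pyridin-2-yl or an unsubstituted phenyl would behave on that chain carbon remains open. Nothing available explains why the nitrogen's location changes the read-out.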